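The source may report more compounds than this note shows. Statements on the series, on what has been measured and on what is new or still open speak of the compounds shown alone.

Measured compounds:
compound 1, `CCc1cnc(N2CCC(n3ncc4cc(-c5ccc(S(C)(=O)=O)cc5)ccc43)CC2)nc1`, 14 nM
compound 2, `CCc1cnc(N2CCC(n3ncc4cc(-c5ccc(S(C)(=O)=O)cc5)c(C)cc43)CC2)nc1`, 70 nM
compound 3, `CCNC(=O)c1ccc(-c2cc3nnn(C4CCN(c5ncc(CC)cn5)CC4)c3cn2)cc1C`, 18 nM

In a functional assay on HEK293 cells for agonist activity at Glucose-dependent insulinotropic receptor (Homo sapiens), read by HTRF and cAMP accumulation, with a stated time of 30 min (on this read-out lower numbers stand for an effect already at smaller amounts and higher numbers for an effect only at larger amounts of compound), compound 1 gives 14 nM. Compound 2 differs from compound 1 by methyl in place of hydrogen on an aromatic carbon, and this gave a 5.0-fold higher number from compound 1 to compound 2 (0.70 log units; beyond the scatter). Compound 3 has a different core; the difference between the two cores is not broken down here. In this assay compound 3 gives 18 nM, a number within the scatter of compound 1.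

Compound 4, `CCNC(=O)c1c(C)cc(-c2cc3nnn(C4CCN(c5ncc(CC)cn5)CC4)c3cn2)cc1C`, is not yet measured. It differs from compound 3 by methyl in place of hydrogen on an aromatic carbon. This is the same kind of change as from compound 1 to compound 2, but not the same: there the methyl entered a ring that is part of a fused or bridged system of two rings, ortho to a 4-(methylsulfonyl)phenyl group, whereas here it enters a ring of carbon only, ortho to an ethylcarbamoyl group and meta to a methyl group. Because the earlier step was a 5.0-fold higher number from compound 1 to compound 2 (0.70 log units; beyond the scatter), a rise of similar direction but uncertain size is expected, estimated as a 2.5-fold higher number from compound 3 to compound 4 (0.40 log units; beyond the scatter). Compound 4 is expected to give 45 nM, between 12 nM and 180 nM.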

Compound 4, half-maximal effective concentration in the Glucose-dependent insulinotropic receptor assay: 27 nM
Compound 4: middle estimate off by 1.7-fold (0.22 log units), on the high side, within the range that was stated.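

In the Glucose-dependent insulinotropic receptor assay the added methyl on the core of compound 3 gave a 1.5-fold higher number from compound 3 to compound 4 (0.18 log units; within the scatter), so on this core the step cannot be told apart from repeat measurement. The change therefore does not carry a fixed size from one core to another, and the step seen on the core of compound 1 was not a reliable guide to its size on the core of compound 3: the same change on two cores in the Glucose-dependent insulinotropic receptor assay, a 5.0-fold higher number (0.70 log units; beyond the scatter) from compound 1 to compound 2 and a 1.5-fold higher number (0.18 log units; within the scatter) from compound 3 to compound 4, 3.3-fold (0.52 log units) apart, beyond the scatter of two such steps These two pairs do not show why the steps differ, as the methyl enters a different ring in each, and two pairs give no rule for other cores in the series.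

In a physicochemical assay for solubility, read by HPLC, in phosphate buffer, measured as thermodynamic solubility, with a stated time of 24 h, at pH 6.8 (a higher number here means a more soluble compound, a lower number a less soluble compound), compound 3 gives 1790 nM and compound 4 gives 5010 nM. On these data alone, it remains open whether the rise in the physicochemical assay would also appear on the core of compound 1: the measured solubility of compound 3, 1790 nM, and of compound 4, 5010 nM, a 2.8-fold higher number (0.45 log units; beyond the scatter) Also open is how a longer chain such as ethyl, or an amine, in place of the new methyl would behave in the Glucose-dependent insulinotropic receptor assay and in the physicochemical assay.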